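Morpholine amide analogue of the urea side chain

This account rests on a few compounds, and the source may have more. Where it says the series, first, only, none or still open, it means among the compounds named here.

Measured compounds:
compound 1 `COc1ncc(-c2ccc3nc(NC(=O)NCC(=O)N4CCCCC4)nn3c2)cc1NS(=O)(=O)c1ccc(F)cc1` gives 130 nM in a functional assay on HCT-116 cells (Homo sapiens) for cytotoxicity, read by MTT assay, with a stated time of 72 h; on this read-out higher numbers stand for weaker inhibition and lower numbers for stronger inhibition
compound 2 `COc1ncc(-c2ccc3nc(NC(=O)N(C)C)nn3c2)cc1NS(=O)(=O)c1ccc(F)cc1` gives 760 nM in this assay
compound 3 `CCCNC(=O)Nc1nc2ccc(-c3cnc(OC)c(NS(=O)(=O)c4ccc(F)cc4)c3)cn2n1` gives 150 nM in this assay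

Compound 2 has the highest number of the three, with compound 3 nearest and compound 1 furthest; both gaps are beyond the scatter, so compound 2 is the weakest of the measured set in this assay.

Compound 4 `COc1ncc(-c2ccc3nc(NC(=O)NCC(=O)N4CCOCC4)nn3c2)cc1NS(=O)(=O)c1ccc(F)cc1` is not yet measured. Compared with compound 2 the change is (((morpholin-4-yl)carbonyl)methyl)amino in place of dimethylamino on a carbonyl carbon. For the measured compounds named here, two measured steps bear on it. a 5.8-fold higher number from compound 1 to compound 2 (0.77 log units; beyond the scatter) shows what the same sort of exchange did with the piperidine relative: the dimethylamino compound was markedly weaker. a 5.1-fold lower number from compound 2 to compound 3 (0.70 log units; beyond the scatter) shows that even a plain propylamino in place of dimethylamino brings a comparable gain. a 1.2-fold higher number from compound 1 to compound 3 (0.06 log units; within the scatter) adds that swapping the piperidinylcarbonyl for ethyl made no difference beyond the scatter, so the terminal ring itself contributes little; a morpholine in that position is expected to behave like the piperidine of compound 1 or the propyl of compound 3.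

The expected step is therefore a modest drop in number, a 5.1-fold lower number from compound 2 to compound 4 (0.70 log units; beyond the scatter), and compound 4 is estimated at 150 nM, with a range of 60 nM to 400 nM.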

Compound 4, half-maximal inhibitory concentration: 490 nM
Compound 4: middle estimate off by 3.3-fold (0.51 log units), on the low side; measured number outside the range, above it.
By their numbers in this assay, from the lowest: compounds 1 and 3 (each within the scatter of the next); then compounds 4 and 2 (each within the scatter of the next).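

In this assay, the terminal ring is no longer a neutral passenger: morpholin-4-yl in place of piperidin-1-yl on the carbonyl carbon costs a step beyond the scatter (a 3.8-fold higher number from compound 1 to compound 4 (0.58 log units; beyond the scatter)), although the earlier exchange of the piperidine amide for ethyl had shown no such change. The extended side chain therefore does not by itself carry the gain over dimethylamino: the morpholine amide stays within the scatter of the dimethylurea (a 1.6-fold lower number from compound 2 to compound 4 (0.19 log units; within the scatter)) and sits beyond the scatter from the propylurea (a 3.3-fold higher number from compound 3 to compound 4 (0.51 log units; beyond the scatter)), so compound 4 goes against any reading in which each longer chain behaves like those of compound 1 and compound 3. No measurement shown here accounts for the difference between the two rings.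

The compounds shown leave open whether the step follows the ring oxygen specifically or any replacement of a ring carbon of the piperidine. A 4-methylpiperazin-1-yl amide, a pyrrolidin-1-yl amide or an open-chain diethylamide at the same place would show whether compound 1 or compound 4 is the better guide to this end of the chain.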